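Acetyl in place of dimethylamino: compound 4

A few compounds are considered here, and "the series" means these few. Any claim that something is new, unique, unknown or untested is made for them only; others in the source may bear on it.

Compound 1 `COc1cc(C)cc(-c2c(-c3ccnc(-c4ccc(N(C)C)cc4)c3)cnn2CC#N)c1` sits at the low end of the three numbers in hand. In a functional assay on UO-31 cells (Homo sapiens) for inhibition, read by sulforhodamine B assay, with a stated time of 48 h (on this read-out higher numbers stand for weaker inhibition of growth and lower numbers for stronger inhibition of growth), compound 1 gives 508 nM. Compound 2 `COc1cc(C)cc(-c2nn(CC#N)cc2-c2ccnc(-c3ccc(N(C)C)cc3)c2)c1` gives 619 nM in this assay, within the scatter of compound 1, so the two cannot be told apart. Compound 3 `Cc1cc(O)cc(-c2nn(CC#N)cc2-c2ccnc(-c3ccc(Oc4ccccc4)cc3)c2)c1` gives 2180 nM, beyond the scatter above compound 1. Compound 4 `COc1cc(C)cc(-c2c(-c3ccnc(-c4ccc(C(C)=O)cc4)c3)cnn2CC#N)c1` is the unmeasured analogue; it differs from compound 1 in one place: acetyl in place of dimethylamino on an aromatic carbon. Among the compounds with values here, no measured pair shows that exchange, so its size is unknown here. A modest move toward weaker inhibition is expected, a 1.8-fold higher number from compound 1 to compound 4 (0.25 log units; within the scatter), close to the edge of the scatter. Compound 4 is therefore estimated at 900 nM, with a range from 350 nM to 2500 nM.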

Compound 4, concentration for 50% growth inhibition: 2610 nM
The estimate for compound 4 lay 2.9-fold (0.46 log units) below the measured number; measured number outside the range, above it.
By their numbers in this assay, from the lowest: compounds 1 and 2 (each within the scatter of the next); then compounds 3 and 4 (each within the scatter of the next).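

In this assay, within the data shown here, the aromatic carbon para to a large group proves sensitive to its substituent: 4-(dimethylamino)phenyl to 4-acetylphenyl gives the first single-place step (a 5.1-fold higher number from compound 1 to compound 4 (0.71 log units; beyond the scatter)), beyond the scatter. The two groups match in heavy-atom count, hydrogen-bond donors and acceptors, and net charge, so those counts do not separate them. No measurement at hand accounts for the step.

Open: whether the same exchange on compound 2 gives a step of similar size, and how a primary amine, a carboxylic acid or a morpholine would read at this position.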